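Chain variation on a biphenyl ester piperidine series

The source may hold more compounds than are shown below. What is called first, only, known or untested is meant among the compounds shown, and "the series" means these compounds.

Measured so far:
- compound 1, `O=C(OCC1CCCN(CCCc2ccccc2)C1)c1ccccc1-c1ccccc1`: 13500 nM; 13500 nM (2 entries)
- compound 2, `O=C(OCC1CCCN(CCCn2cc(-c3ccccc3)nn2)C1)c1ccccc1-c1ccccc1`: 6460 nM

Both measured compounds share the biphenyl ester core and the ring amine, differing only in the chain on that nitrogen. In an in vitro functional assay on HEK ts201 cells for antagonist activity at Neuronal acetylcholine receptor; alpha4/beta2 (Homo sapiens), read by fluorescence and calcium flux (on this read-out lower numbers stand for stronger inhibition and higher numbers for weaker inhibition), compound 1 gives 13500 nM; 13500 nM (2 entries) in two separate entries, and compound 2 gives 6460 nM. Going by the values given here, for compound 2 this is the only number recorded; a further entry gives no single number. Among the compounds with values here, no step between measured compounds is available.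

Compound 3, `O=C(OCC1CCCN(CCCCCOc2ccc(Cl)cc2)C1)c1ccccc1-c1ccccc1`, has not been measured in this assay. Its change from compound 2 is 2-(4-chlorophenoxy)ethyl in place of 4-phenyl-1H-1,2,3-triazol-1-yl on a saturated chain carbon, three bonds along the chain from an amine nitrogen in a ring. Nothing measured here speaks directly to this change, so the step is expected to stay within the scatter: the estimated step from compound 2 to compound 3 is a 1.2-fold higher number from compound 2 to compound 3 (0.09 log units; within the scatter), with no clear direction. Compound 3 is expected to give 8000 nM, in the range 2500 nM to 25000 nM.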

Compound 3, half-maximal inhibitory concentration: 14500 nM
The estimate for compound 3 lay 1.8-fold (0.26 log units) below the measured number; measured number inside the range.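

In this assay, going by these compounds alone, the exchange of 4-phenyl-1H-1,2,3-triazol-1-yl for 2-(4-chlorophenoxy)ethyl gives a 2.2-fold higher number from compound 2 to compound 3 (0.35 log units; beyond the scatter), the first readable step, showing that this saturated chain carbon responds modestly to the group it carries, with the triazole-bearing compound 2 giving the lower number. The change is not a single-feature edit: a five-membered aromatic ring with three hetero atoms leaves, while oxygen and chlorine enter and the hydrogen-bond acceptor count falls, so the step cannot be assigned to one of these differences. No measurement here bears on the origin of the step.

Still open, on these data alone, is which part of the change carries the step: the chlorine, the oxygen or the departure of the triazole ring. Also open, as far as these compounds go, is how an amine or a carboxylic acid on the same saturated chain carbon would read in this assay.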